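This account rests on a few compounds, and the source may have more. Where it says the series, first, only, none or still open, it means among the compounds named here.

Compound 1, `Cc1cc(NCc2ccccn2)n2ncc(-c3ccc(C(F)(F)F)cc3)c2n1`: in a physicochemical assay for solubility, read by HPLC, using the shake flask method, measured as kinetic solubility, with a stated time of 2 h, at pH 7.4 (on this read-out lower numbers stand for lower solubility and higher numbers for higher solubility), compound 1 gives < 5000 nM, which is a limit of the assay.
Compound 2, `Cc1cc(NCc2ccccn2)n2ncc(-c3ccc(C#N)cc3)c2n1`: in this assay compound 2 gives < 5000 nM, again a limit of the assay.
Compound 3, `Cc1cc(NCc2ccccn2)n2ncc(-c3ccc(C(=O)Nc4ccccc4)cc3)c2n1`: in this assay compound 3 gives 5000 nM.

Compound 2 therefore stands only as a limit, at the limit of < 5000 nM in this assay, at which 2 of the 3 values shown sit, and no number separates it from compound 1. The step that the two limits leave unreadable from compound 1 to compound 2 cannot be read. Within the data shown here, the steps of a number no lower from compound 1 to compound 3 (the limit leaves the size open) and a number no lower from compound 2 to compound 3 (the limit leaves the size open) show only that compound 3 is no lower than either, with the size left open.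

Compound 4, `Cc1cc(NCc2ccccn2)n2ncc(C3=CCOCC3)c2n1`, differs from compound 2 in one place: a group of 6 heavy atoms (5 carbon, 1 oxygen; one six-membered non-aromatic ring with 1 hetero atom) in place of a group of 8 heavy atoms (7 carbon, 1 nitrogen; one six-membered aromatic ring of carbon only), on an aromatic carbon. Among the measured compounds shown here, none of the measured steps follows this kind of change, so the expectation rests on the position of compound 2 at its limit. The step of an at least 1.2-fold higher number from compound 2 to compound 4 (0.07 log units; that floor lies within the scatter) is expected to be modest and upward, without confidence in its size. Compound 4 is estimated at 6000 nM, within a range from 2000 nM to 25000 nM.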

Compound 4, solubility: 171000 nM
Beside the measured number, compound 4's estimate is 29-fold (1.45 log units) below it, and the stated range ends below it.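

Earlier, the changes were made only within the group on the aromatic ring at this position, and none of those steps gave a readable size. In this assay, replacing the whole 4-cyanophenyl with a six-membered non-aromatic ring with 1 hetero atom gives an at least 34-fold higher number from compound 2 to compound 4 (1.53 log units; beyond the scatter), which shows that this place, on an aromatic carbon of the five-membered aromatic ring, can carry a large change on this read-out. That step is a floor rather than a size, because compound 2 stands only as a limit of the assay: the limit of < 5000 nM in this assay, at which 2 of the 4 values shown sit.

The compounds shown do not separate the contributions of the ring oxygen, the ring double bond and the loss of the aromatic ring. Going by these compounds, how a cyclohexenyl ring, a tetrahydropyranyl ring or a piperidine would read at this place remains open.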